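This account rests on a few compounds, and the source may have more. Where it says the series, first, only, none or still open, it means among the compounds named here.

Measured in a physicochemical assay for lipophilicity, using the shake flask method, in phosphate buffer, measured as octanol-water partition, with a stated time of 30 min, at pH 7.4; on this read-out lower numbers stand for lower lipophilicity and higher numbers for higher lipophilicity:
- compound 1 `Cc1nccn1-c1cnc(NCc2c(F)ccc3c2CCO3)c2cn[nH]c(=O)c12`: 2.1
- compound 2 `O=C1CCCN1c1cnc(NCc2c(F)ccc3c2CCO3)c2cn[nH]c(=O)c12`: 1.8
- compound 3 `Cc1nc(CN(C)C)ccc1-c1cnc(NCc2c(F)ccc3c2CCO3)c2cn[nH]c(=O)c12`: 2

Compound 3 gives 2 and stands within the scatter of both other compounds, with steps of a number 0.10 log units lower from compound 1 to compound 3 (within the scatter) and a number 0.20 log units higher from compound 2 to compound 3 (within the scatter). In this assay, these three numbers therefore cannot be ranked.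

Compound 4 `CNC(=O)c1cc(-c2cnc(NCc3c(F)ccc4c3CCO4)c3cn[nH]c(=O)c23)n(C)n1` has not been measured yet. On the same aromatic carbon of the shared core, 1-methyl-3-(methylcarbamoyl)-1H-pyrazol-5-yl takes the place of 6-((dimethylamino)methyl)-2-methylpyridin-3-yl: 1-methyl-3-(methylcarbamoyl)-1H-pyrazol-5-yl in place of 6-((dimethylamino)methyl)-2-methylpyridin-3-yl on an aromatic carbon.

The steps above bear on this exchange, together with the third measured one, a number 0.30 log units lower from compound 1 to compound 2 (within the scatter). All three replace one group on this carbon with another and stay within the scatter. None of them brings in this pyrazole, so they offer only a rough guide.

No step beyond the scatter is expected, and the estimated step is a number 0.20 log units lower from compound 3 to compound 4 (within the scatter). The estimate for compound 4 is 1.8, with an expected range from 1.3 to 2.3.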

Compound 4, distribution coefficient: 2.1
For compound 4 the middle estimate is 0.30 log units below the measured one; the measured number falls inside the stated range.
By their numbers in this assay, from the lowest: compounds 2, 3, 1 and 4 (each within the scatter of the next).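

In this assay, 1-methyl-3-(methylcarbamoyl)-1H-pyrazol-5-yl now joins the three earlier groups on this aromatic carbon, and all the new steps stay small: a number 0.10 log units higher from compound 3 to compound 4 (within the scatter) and a number 0.30 log units higher from compound 2 to compound 4 (within the scatter) and no change at the digits printed from compound 1 to compound 4 (within the scatter). Unlike the 6-((dimethylamino)methyl)-2-methylpyridin-3-yl group it replaces, this group has a five-membered aromatic ring and a hydrogen-bond donor, yet even this exchange does not produce a step beyond the scatter. Nothing measured here explains why the four numbers lie so close together.

As far as these compounds go, whether a carboxylic acid or a longer alkyl chain on this carbon would produce a step beyond the scatter remains open. These compounds also leave open whether the same exchanges would stay as small on a different core.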